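Adding a chloro to a compound at the assay limit

The source may hold more compounds than are shown below. What is called first, only, known or untested is meant among the compounds shown, and "the series" means these compounds.

Compound 1 `COc1ccc(/C=C/C(=O)/C=C/c2cc3ccccc3nc2Oc2ccccc2)cc1` gives > 10000 nM
Compound 2 `COc1ccc(/C=C/C(=O)/C=C/c2cc3ccccc3nc2Oc2ccccc2)c(OC)c1` gives > 10000 nM

Both entries come from a functional assay on NCI-H460 cells (Homo sapiens) for cytotoxicity, read by MTT assay, with a stated time of 48 h; on this read-out lower numbers stand for stronger inhibition and higher numbers for weaker inhibition. Compound 2 stands at > 10000 nM, which is a limit of the assay and not a number. Compound 1 also stands at a limit.

Compound 3 `COc1ccc(/C=C/C(=O)/C=C/c2cc3ccccc3nc2Oc2cccc(Cl)c2)c(OC)c1` differs from compound 2 in one place: chloro in place of hydrogen on an aromatic carbon. In plain terms, a phenoxy becomes a 3-chlorophenoxy. Going by the values given here, the one measured step, a step that the two limits leave unreadable from compound 1 to compound 2, brought in a methoxy rather than a chloro, and it offers no size to carry over. Among the compounds with values here, the only other guide is the limit of > 10000 nM in this assay, at which 2 of the 2 values shown sit. On that basis, compound 3 is expected to stay near this limit in this assay, with neither direction favoured, and it may be reported only as a limit. The expected change is a step that the limit leaves unreadable from compound 2 to compound 3. For compound 3, the estimated value is 12000 nM, with an expected range from 4000 nM to 30000 nM.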

Compound 3, half-maximal inhibitory concentration: > 10000 nM
Compound 3 was reported as a limit (the forecaster's own chance of this, stated with the estimate: 70%); the middle value does not contradict the limit.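

Compound 2 and compound 3 both stand at a limit of the assay rather than at a number, so no size can be read for the step between them. The compounds shown leave open whether the chloro changes the cytotoxicity in this assay at all.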